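Azide for Acetoxy: Expected Cytotoxicity of Compound 3

This account rests on a few compounds, and the source may have more. Where it says the series, first, only, none or still open, it means among the compounds named here.

Compound 1 `CCOC(=O)c1csc([C@H]2[C@@H](COC)C[C@@](CC(C)C)(C(=O)O)N2C(=O)c2ccc(C(C)(C)C)c(OC)c2)n1` in an ADME assay on Huh-5-2 cells (Homo sapiens) for cytotoxicity, with a stated time of 3 days (on this read-out higher numbers stand for lower toxicity in this test and lower numbers for higher toxicity in this test), gives 200000 nM.
Compound 2 `COC[C@H]1C[C@@](CC(C)C)(C(=O)O)N(C(=O)c2ccc(C(C)(C)C)c(OC)c2)[C@H]1COC(C)=O` gives > 120000 nM, which is a limit of the assay, not a number.

Compound 2 therefore stands only at a limit. The step that the limit leaves unreadable from compound 1 to compound 2 cannot be sized because of the limit of > 120000 nM in this assay, at which 1 of the 2 values shown sits. Compound 3 `COC[C@H]1C[C@@](CC(C)C)(C(=O)O)N(C(=O)c2ccc(C(C)(C)C)c(OC)c2)[C@H]1CN=[N+]=[N-]` differs from compound 2 by azido in place of acetoxy on a saturated chain carbon bound to a saturated ring carbon. Among the measured compounds shown here, no measured step reads out a size for a change of this kind, so no shift beyond the scatter is expected. Compound 3 is estimated at 150000 nM, within 60000 nM to 400000 nM, a step that the limit leaves unreadable from compound 2 to compound 3, most likely again reported only as a limit.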

Compound 3, half-maximal cytotoxic concentration: > 120000 nM
Compound 3: only a limit was reported (the forecaster's own chance of this, stated with the estimate: 70%); the middle value is on the limit's open side.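

Among the compounds shown here, no step can be sized among compound 1, compound 2 and compound 3, because the results stop at a limit: the limit of > 120000 nM in this assay, at which 2 of the 3 values shown sit. The compounds shown leave open how compound 2 and compound 3 truly compare with each other and with compound 1 in this assay.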